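The source may report more compounds than this note shows. Statements on the series, on what has been measured and on what is new or still open speak of the compounds shown alone.

Measured in a functional assay on MCF7 cells (Homo sapiens) for inhibition, read by MTT assay, with a stated time of 72 h; on this read-out higher numbers stand for weaker inhibition and lower numbers for stronger inhibition:
compound 1 `CN(C(=O)NC(=O)c1ccc(Cl)c(Cl)c1)c1nc(C(F)(F)F)c(C(=O)N/N=C/c2ccc([N+](=O)[O-])cc2)s1` gives 6.74 ug/mL;
compound 2 `CN(C(=O)NC(=O)c1ccccc1)c1nc(C(F)(F)F)c(C(=O)N/N=C/c2cccc([N+](=O)[O-])c2)s1` gives 15.4 ug/mL.

Compound 2 stands at the higher of the two numbers, and the gap to compound 1 lies beyond the usual scatter. Compound 3 `CN(C(=O)NC(=O)c1ccc(Cl)c(Cl)c1)c1nc(C(F)(F)F)c(C(=O)N/N=C/c2cccc([N+](=O)[O-])c2)s1` differs from compound 2 by 3,4-dichlorophenyl in place of phenyl on a carbonyl carbon. Within the data shown here, no pair of measured compounds isolates this swap, so its size is uncertain; the direction is drawn from compound 1, which also carries 3,4-dichlorophenyl and gives 6.74 ug/mL. The swap is expected to bring a modest step toward a lower number, a 1.7-fold lower number from compound 2 to compound 3 (0.23 log units; within the scatter). Compound 3 is estimated at 9 ug/mL, within 4 ug/mL to 20 ug/mL.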

Compound 3, half-maximal inhibitory concentration: 7.51 ug/mL
Beside the measured number, compound 3's estimate is 1.2-fold (0.08 log units) above it; the range from low to high includes it.
By their numbers in this assay, from the lowest: compounds 1 and 3 (each within the scatter of the next); then compound 2.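

In this assay the swap to 3,4-dichlorophenyl from phenyl on a carbonyl carbon now stands alone, and it gives a 2.1-fold lower number from compound 2 to compound 3 (0.31 log units; beyond the scatter) with nothing else altered. The other swap, 3-nitrophenyl in place of 4-nitrophenyl on a carbon with a double bond to nitrogen, gives a 1.1-fold higher number from compound 1 to compound 3 (0.05 log units; within the scatter) and so cannot be told apart here. The group on the carbonyl carbon thus registers in this read-out while the nitro placement does not, and no data at hand explain why. As far as these compounds go, whether a single chlorine, a methoxy group or an amine on that ring would do the same stays open.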